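The source may hold more compounds than are shown below. What is called first, only, known or untested is meant among the compounds shown, and "the series" means these compounds.

Compound 1 `O=c1[nH]/c(=N\OCCCCc2ccccc2)ccn1[C@@H]1O[C@H](COP(=O)(O)OP(=O)(O)OP(=O)(O)O)[C@@H](O)[C@H]1O` gives 251 nM in a functional assay on 1321-N1 cells for agonist activity at P2Y purinoceptor 6 (Homo sapiens), read by scintillation counting and inositol phosphate accumulation; a lower number here means that less compound is needed, a higher number that more compound is needed for the effect.
Compound 2 `O=c1[nH]/c(=N\OCCCc2ccc(I)cc2)ccn1[C@@H]1O[C@H](COP(=O)(O)OP(=O)(O)OP(=O)(O)O)[C@@H](O)[C@H]1O` gives 90 nM in this assay.

Among the compounds with values here, compound 2 holds the lowest of the two numbers measured so far; its only neighbour is compound 1, and the step of a 2.8-fold lower number from compound 1 to compound 2 (0.45 log units; beyond the scatter) is the single measured change in this small set. Compound 3 `O=c1[nH]/c(=N\OCCCc2ccncc2)ccn1[C@@H]1O[C@H](COP(=O)(O)OP(=O)(O)OP(=O)(O)O)[C@@H](O)[C@H]1O` is the next compound in line. It differs from compound 2 by pyridin-4-yl in place of 4-iodophenyl on a saturated chain carbon, three bonds along the chain from an oxygen.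

Within the data shown here, only one measured step bears on this change, a 2.8-fold lower number from compound 1 to compound 2 (0.45 log units; beyond the scatter), which showed that exchanging the group on the saturated chain carbon, three bonds along the chain from an oxygen, moves the number beyond the scatter. Among the measured compounds shown here, no measured compound carries a ring with a hetero atom at that place, so the data give no direct guide to the direction. For the measured compounds named here, since the one measured change at this position was of modest size, a modest shift is expected here too, and the account treats a rise toward the level of compound 1 as the more likely outcome: compound 3 is expected to show a 2.8-fold higher number from compound 2 to compound 3 (0.44 log units; beyond the scatter). The estimate for compound 3 in this assay is therefore 250 nM, with a range from 80 nM to 800 nM.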

Compound 3, half-maximal effective concentration: 4280 nM
Beside the measured number, compound 3's estimate is 17-fold (1.23 log units) below it, outside the stated range (above it).
By their numbers in this assay, from the lowest: compound 2; then compound 1; then compound 3.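

In this assay, within the data shown here, pyridin-4-yl in place of 4-iodophenyl gave a 48-fold higher number from compound 2 to compound 3 (1.68 log units; beyond the scatter), a large step where the only earlier change at this place had been modest. Measured against the benzyl group of compound 1, the same exchange still gave a 17-fold higher number from compound 1 to compound 3 (1.23 log units; beyond the scatter), so the six-membered aromatic ring with 1 hetero atom falls well apart from both rings of carbon only, and the group on a saturated chain carbon, three bonds along the chain from an oxygen, can move the number much further than the first step suggested. Nothing measured alongside these numbers accounts for the size of this rise.

The compounds shown leave open whether the outcome follows from the ring nitrogen as such or from where it stands, and pyridin-3-yl and pyridin-2-yl would bear directly on that question. Going by these compounds, it also remains open whether 4-bromophenyl, 4-methoxyphenyl or 4-aminophenyl at this place would give a number closer to that of compound 2 or to that of compound 3.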